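Compound 4 and the limit of the toxicity read-out

The compounds below may be only part of what the source reports. "The series", "measured", "known", "first", "only" and "open" are said of these compounds alone.

In an ADME assay on NIH3T3 cells (Mus musculus) for cytotoxicity (on this read-out higher numbers stand for lower toxicity in this test and lower numbers for higher toxicity in this test), compound 1 `CC(C)(C)CC#Cc1cc2ncnc(Nc3ccc(OCc4cccc(F)c4)c(Cl)c3)c2s1` reports only a limit, > 50 uM. Compound 2 `CN(C)CC#Cc1cc2ncnc(Nc3ccc(OCc4cccc(F)c4)c(Cl)c3)c2s1` also reports only a limit, > 50 uM, and so stands at the limit of > 50 uM in this assay, at which 2 of the 3 values shown sit. Compound 3 `CC(C)(C)OC(=O)N1CCN(CC#Cc2cc3ncnc(Nc4ccc(OCc5cccc(F)c5)c(Cl)c4)c3s2)CC1` gives a number, 47 uM.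

Compound 4 `CC(C)CC#Cc1cc2ncnc(Nc3ccc(OCc4cccc(F)c4)c(Cl)c3)c2s1` differs from compound 2 by isopropyl in place of dimethylamino on a saturated chain carbon bound to a triple-bonded carbon, with isopropyl in place of dimethylamino on a saturated chain carbon bound to a triple-bonded carbon. Within the data shown here, the one measured step at that place, a step that the two limits leave unreadable from compound 1 to compound 2, offers no size to carry over. Compound 1, with tert-butyl there, still reports the limit > 50 uM, so no change beyond the scatter is expected in this assay. The estimated step is a number no higher from compound 2 to compound 4 (the limit leaves the size open). For compound 4 the expected value is 50 uM, with an estimated range of 25 uM to 100 uM.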

Compound 4, half-maximal toxic concentration: > 50 uM
Compound 4: no number, only a limit; the forecaster's own chance of this, stated with the estimate: 65%; the middle value lies on the limit itself.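

In this assay, among these compounds, compound 4 reports only a limit, > 50 uM, so no step from compound 1 or compound 2 to compound 4 can be read. Going by these compounds, whether isopropyl, tert-butyl and dimethylamino differ on this read-out stays open.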